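Swapping a phenoxy arm for a fluoroanilino group

The source may report more compounds than this note shows. Statements on the series, on what has been measured and on what is new or still open speak of the compounds shown alone.

Three compounds share one core and were tested in a functional assay on HCT-116 cells (Homo sapiens) for antiproliferative activity; a higher number here means a weaker inhibitor of growth, a lower number a stronger inhibitor of growth:
- compound 1 `Cc1cc(-c2cnn3c(NCC4CCOCC4)nc(NC4CCOCC4)nc23)ccc1C(=O)NC1CC1` gives 280 nM
- compound 2 `CN(c1nc(NCC2CCOCC2)n2ncc(-c3ccc(C(=O)NC4CC4)c(F)c3)c2n1)C1CCCCC1` is recorded as "not determined" (no result reported)
- compound 3 `CC(=O)Nc1cccc(Oc2nc(NCC3CCOCC3)n3ncc(-c4ccc(C(=O)NC5CC5)c(C)c4)c3n2)c1` gives 1300 nM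

Compound 3 thus has the higher of the two numbers, with compound 1 showing a 4.6-fold higher number from compound 1 to compound 3 (0.67 log units; beyond the scatter) step below it. Compound 4 `Cc1cc(-c2cnn3c(NCC4CCOCC4)nc(Nc4ccccc4F)nc23)ccc1C(=O)NC1CC1` differs from compound 3 by (2-fluorophenyl)amino in place of 3-acetamidophenoxy on an aromatic carbon. Among the measured compounds shown here, the only measured step at this position, a 4.6-fold higher number from compound 1 to compound 3 (0.67 log units; beyond the scatter), shows that replacing a small amino group here by the acetamidophenoxy arm raised the number modestly; compound 4 removes that arm again and installs a smaller amino group, so a move back toward compound 1 is expected, a 2.9-fold lower number from compound 3 to compound 4 (0.46 log units; beyond the scatter). Compound 4 is therefore estimated at 450 nM, within 150 nM to 1500 nM.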

Compound 4, concentration for 50% growth inhibition: 21 nM
Compound 4: the middle estimate sits 21-fold (1.33 log units) above what was measured; measured number below the stated range.
By their numbers in this assay, from the lowest: compound 4; then compound 1; then compound 3.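

In this assay, among the compounds shown here, the step of a 62-fold lower number from compound 3 to compound 4 (1.79 log units; beyond the scatter) shows that this position can move the number much further than the earlier compounds suggested. A ring on the nitrogen can also beat the oxan-4-yl group, as the step of a 13-fold lower number from compound 1 to compound 4 (1.12 log units; beyond the scatter) shows for 2-fluorophenyl in its place. No supporting measurement explains either change.

As far as these compounds go, whether a plain phenylamino or a (2-chlorophenyl)amino group would match compound 4 remains open, so the share of the fluorine is unknown. Also open, from the compounds shown here alone, is how much of the first change comes from the nitrogen link and how much from losing the acetamido group.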